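A few compounds are considered here, and "the series" means these few. Any claim that something is new, unique, unknown or untested is made for them only; others in the source may bear on it.

The measured compounds and their values:

Compound 1, `Cc1cc2nc(N)nc(N)c2c(=O)[nH]1`, gives 26%.
Compound 2, `Cc1cc2nc(-c3ccccc3)nc(N)c2c(=O)[nH]1`, gives 22%.

Both numbers come from an assay on isolated protein for inhibition of MAP kinase-activated protein kinase 2 (Homo sapiens), read by mobility shift assay, tested at 30 uM; on this read-out higher numbers stand for more inhibition at the one concentration tested (going by the name of the read-out) and lower numbers for less inhibition. For the measured compounds named here, on these two numbers compound 2 stands lowest, with compound 1 as its nearest neighbour, yet the only measured step, a number 4 percentage points lower from compound 1 to compound 2 (within the scatter), lies within the scatter, so the two compounds cannot be told apart on this read-out.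

Compound 3, `Cc1nc(N)c2c(=O)[nH]c(C)cc2n1`, differs from compound 2 in one place: methyl in place of phenyl on an aromatic carbon.

Going by the values given here, no measured step swaps phenyl for methyl, so there is no direct guide. Among the compounds with values here, the one step that touches this same place, a number 4 percentage points lower from compound 1 to compound 2 (within the scatter), shows that exchanging amino for phenyl there left the number within the scatter. Because that step, a number 4 percentage points lower from compound 1 to compound 2 (within the scatter), was so small, no step beyond the scatter is expected here either, and the expected step is a number 2 percentage points higher from compound 2 to compound 3 (within the scatter). Compound 3 is therefore estimated at 24%, with a range from 10% to 38%.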

Compound 3, a percentage reported as inhibition, at one concentration (the size of the read-out at that concentration, not a potency): 18%
The estimate for compound 3 lay 6 percentage points above the measured number; low and high end bracket the measured number.
By their numbers in this assay, from the lowest: compounds 3, 2 and 1 (each within the scatter of the next).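

In this assay, putting methyl in place of phenyl gives a number 4 percentage points lower from compound 2 to compound 3 (within the scatter) and putting methyl in place of amino gives a number 8 percentage points lower from compound 1 to compound 3 (within the scatter) at this aromatic carbon between two ring nitrogen atoms. Until now, this position had been probed only with amino and phenyl, so this result adds a third kind of group: a single carbon with no ring, set against a six-carbon aromatic ring and an amino group. None of the three exchanges moves the reading beyond the usual scatter, so on these compounds the assay does not distinguish the three groups, and no measurement at hand offers an explanation for that.

The compounds shown leave open whether a group of a different kind at this position, such as a carboxylic acid, a longer chain like butyl, or a cyclic amine like morpholine, would move the reading beyond the scatter. They also leave open whether changes elsewhere on the shared core, for instance replacing the methyl on the ring that carries the carbonyl, would matter more than this position has so far.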